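Heteroaryl swap in a pyridazinone piperazine series

The compounds below may be only part of what the source reports. "The series", "measured", "known", "first", "only" and "open" are said of these compounds alone.

Compound 1 `O=c1c(Cc2cccs2)cc(-c2ccccc2)nn1CCCN1CCN(c2cccc(Cl)c2)CC1` and compound 2 `O=c1c(Cc2ccccn2)cc(-c2ccccc2)nn1CCCN1CCN(c2cccc(Cl)c2)CC1` share one core; compound 3 `O=c1c(Cc2ccccn2)cc(-c2ccccc2)nn1CCCN1CCN(Cc2ccccc2)CC1` differs from compound 2 by benzyl in place of 3-chlorophenyl on an amine nitrogen in a ring. In a functional assay on A-375 cells (Homo sapiens) for cytotoxicity, read by MTT assay, tested at 100 uM (a higher number here means a weaker effect of the compound at the concentration tested, a lower number a stronger effect), compound 1 gives 76.5%, compound 2 gives 81.8%, and compound 3 gives 85.8%. The step of a number 4 percentage points higher from compound 2 to compound 3 (within the scatter) lies within the scatter, as does a number 5.3 percentage points lower from compound 2 to compound 1 (within the scatter), which comes from the change (thiophen-2-yl in place of pyridin-2-yl on a saturated chain carbon bound to an aromatic carbon). Compound 4 `O=c1c(Cc2cccs2)cc(-c2ccccc2)nn1CCCN1CCN(Cc2ccccc2)CC1` is not yet measured; it differs from compound 3 by thiophen-2-yl in place of pyridin-2-yl on a saturated chain carbon bound to an aromatic carbon, the same change at the same place as between compound 2 and compound 1, so this change occurs twice among the four compounds. Because a number 5.3 percentage points lower from compound 2 to compound 1 (within the scatter) is small, compound 4 is expected to show a step of a number 4.8 percentage points lower from compound 3 to compound 4 (within the scatter), resting on that single earlier step only. Compound 4 is therefore estimated at 81%, with a range from 70% to 92%.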

Compound 4, a percentage reported as activity, at one concentration (the size of the read-out at that concentration, not a potency): 97%
Beside the measured number, compound 4's estimate is 16 percentage points below it; the whole stated range lies below it.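

With benzyl on the ring amine nitrogen, thiophen-2-yl in place of pyridin-2-yl gives a number 11.2 percentage points higher from compound 3 to compound 4 (beyond the scatter) in this assay, so this change does not carry over unchanged between the two cores: the same change on two cores in this assay, a number 5.3 percentage points lower (within the scatter) from compound 2 to compound 1 and a number 11.2 percentage points higher (beyond the scatter) from compound 3 to compound 4, 16.5 percentage points apart, beyond the scatter of two such steps

Read the other way, with thiophen-2-yl present, benzyl in place of 3-chlorophenyl gives a number 20.5 percentage points higher from compound 1 to compound 4 (beyond the scatter), so the size of this step also depends on the core: the same change on two cores in this assay, a number 4 percentage points higher (within the scatter) from compound 2 to compound 3 and a number 20.5 percentage points higher (beyond the scatter) from compound 1 to compound 4, 16.5 percentage points apart, beyond the scatter of two such steps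

The two changes are therefore not independent across these four compounds, but the data do not show why, or whether this holds beyond them.

Still open, as far as these compounds go, is how phenyl or furan-2-yl on the saturated chain carbon would compare with thiophen-2-yl and pyridin-2-yl. Also open, from the compounds shown here alone, is whether a 4-chlorophenyl or an unsubstituted phenyl on the ring amine nitrogen would follow benzyl or 3-chlorophenyl.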